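Replacing isopropyl on the indole-type nitrogen of compound 2

The compounds below may be only part of what the source reports. "The series", "measured", "known", "first", "only" and "open" are said of these compounds alone.

The series shares one core, seen in compound 1 `COc1ccc(NC(=O)C(=O)c2cn(C(C)C)c3c(Cl)cccc23)cn1` and compound 2 `COc1ccc(NC(=O)C(=O)c2cn(C(C)C)c3ccccc23)cn1`. Going by the values given here, in a functional assay on FaDu cells (Homo sapiens) for cytotoxicity, read by MTT assay, with a stated time of 72 h (a lower number here means that less compound is tolerated, a higher number that more compound is tolerated), compound 1 gives 10200 nM, while compound 2 gives 85 nM, the lowest of the two numbers measured so far. Among the compounds with values here, the only measured step, a 120-fold lower number from compound 1 to compound 2 (2.08 log units; beyond the scatter), concerns the aromatic carbon and not the aromatic nitrogen, so it does not bear on the change now considered.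

Compound 3 `COc1ccc(NC(=O)C(=O)c2cn(CC3CCCO3)c3ccccc23)cn1` differs from compound 2 by (oxolan-2-yl)methyl in place of isopropyl on an aromatic nitrogen. Within the data shown here, no measured pair changes the group on the aromatic nitrogen, so the effect of this exchange is unknown from the data; the change keeps the part of the molecule that separated compound 1 from compound 2 untouched. The expectation for a 1.3-fold higher number from compound 2 to compound 3 (0.11 log units; within the scatter) is therefore no step beyond the scatter. Compound 3 is estimated at 110 nM, with a range from 30 nM to 450 nM.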

Compound 3, concentration lethal to 50% of the cells: 31 nM
The estimate for compound 3 lay 3.5-fold (0.55 log units) above the measured number, and the stated range covers the measured number.
By their numbers in this assay, from the lowest: compound 3; then compound 2; then compound 1.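

The group on the aromatic nitrogen of the shared core also moves the number in this assay: (oxolan-2-yl)methyl in place of isopropyl gives a 2.7-fold lower number from compound 2 to compound 3 (0.44 log units; beyond the scatter), a modest step. This position therefore accepts a group with more heavy atoms, a five-membered non-aromatic ring and a hydrogen-bond acceptor, and the number still falls rather than rises. Nothing available explains this step.

Going by these compounds alone, with only this one pair, the ring and the oxygen of the (oxolan-2-yl)methyl group cannot be told apart as the source of the step, and an open-chain ether such as 2-methoxyethyl would be needed to separate them. As far as these compounds go, how an amine, a carboxylic acid or a longer chain on this nitrogen would behave remains open, as does whether chloro on the aromatic carbon, as in compound 1, would have the same effect alongside (oxolan-2-yl)methyl.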